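A few compounds are considered here, and "the series" means these few. Any claim that something is new, unique, unknown or untested is made for them only; others in the source may bear on it.

Measured in a functional assay on MCF7 cells (Homo sapiens) for antiproliferative activity, read by MTT assay, with a stated time of 48 h; a higher number here means a weaker inhibitor, a lower number a stronger inhibitor:
- compound 1 `COC(=O)[C@H](CC(C)C)NC(=O)c1ccc(Oc2nc3cc(Cl)ccc3nc2C)cc1`: 19100 nM
- compound 2 `COC(=O)CNC(=O)c1ccc(Oc2nc3ccccc3nc2NC(C)(C)C)cc1`: > 50000 nM

Compound 2 gives > 50000 nM, which is a limit of the assay and not a number.

Compound 3 `CC[C@@H](C)[C@H](NC(=O)c1ccc(Oc2nc3ccccc3nc2NC(C)(C)C)cc1)C(=O)O` carries 1-carboxy-2-methylbutyl in place of (methoxycarbonyl)methyl on an amide-type nitrogen. Within the data shown here, no measured pair isolates this change, so any expectation for this assay is loose. A small move towards a lower number is expected, and another reading at the limit remains quite possible. Among the measured compounds shown here, the expectation stays near the weak end of the series, with compound 1 at 19100 nM as the only numeric reading so far. The expected step is an at least 1.2-fold lower number from compound 2 to compound 3 (0.09 log units; that floor lies within the scatter). For compound 3 the estimated value is 40000 nM, with an expected range of 12000 nM to 90000 nM.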

Compound 3, half-maximal inhibitory concentration: 11400 nM
Estimate against measurement, compound 3: 3.5-fold (0.55 log units) above; the measured number lies below the stated range.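

Among these compounds, on the amide-type nitrogen, 1-carboxy-2-methylbutyl in place of (methoxycarbonyl)methyl gives the first readable step in this assay: an at least 4.3-fold lower number from compound 2 to compound 3 (0.64 log units; beyond the scatter). Compound 1 and compound 2 differ in more than one place and could not isolate this position, whereas this pair shows that the group on this nitrogen alone can bring a reading off the limit with the shared core unchanged. The size of the step is only a floor, because compound 2 stands at a limit of the assay and not at a number: the limit of > 50000 nM in this assay, at which 1 of the 3 values shown sits.

The compounds shown leave open whether the carboxy group or the larger branched chain carries the step, since 1-carboxy-2-methylbutyl differs from (methoxycarbonyl)methyl in both. A carboxymethyl group or a 1-(methoxycarbonyl)-2-methylbutyl group on the same nitrogen would separate the two.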